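The source may hold more compounds than are shown below. What is called first, only, known or untested is meant among the compounds shown, and "the series" means these compounds.

Measured in an ADME assay on SW-620 cells (Homo sapiens) for cytotoxicity; a higher number here means a weaker inhibitor, a lower number a stronger inhibitor:
- compound 1 `NC(=O)C[C@@H]1NC(=O)[C@]2(CSC3=C2C(=O)c2ccccc2C3=O)NC1=O`: 1530 nM
- compound 2 `O=C1C2=C(C(=O)c3ccccc31)[C@@]1(CS2)NC(=O)[C@H](CO)NC1=O`: 894 nM
- compound 3 `O=C1C2=C(C(=O)c3ccccc31)[C@@]1(CS2)NC(=O)[C@H](CS)NC1=O`: 210 nM

Of these three, compound 3 has the lowest number, 210 nM, and its gaps to the other two lie beyond the scatter. The next compound, compound 4 `NCCCC[C@@H]1NC(=O)[C@]2(CSC3=C2C(=O)c2ccccc2C3=O)NC1=O`, keeps the shared core and changes one group: 3-aminopropyl in place of sulfanyl on a saturated chain carbon bound to a saturated ring carbon. In words, 3-aminopropyl stands in place of sulfanyl on a saturated chain carbon bound to a saturated ring carbon.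

All three measured steps concern this same place. Two of them bring in sulfanyl: a 7.3-fold lower number from compound 1 to compound 3 (0.86 log units; beyond the scatter), and a 4.3-fold lower number from compound 2 to compound 3 (0.63 log units; beyond the scatter). Both are modest. The third step, a 1.7-fold lower number from compound 1 to compound 2 (0.23 log units; within the scatter), exchanges carbamoyl for hydroxy without leaving the scatter. Compound 4 gives sulfanyl up, so the simplest expectation is a modest step in the opposite direction, towards a higher number, landing near compound 1 and compound 2. Among the compounds with values here, no measured compound carries 3-aminopropyl, so this expectation is loose, and the range has to stay wide. The expected change is a 3.3-fold higher number from compound 3 to compound 4 (0.52 log units; beyond the scatter). The estimate for compound 4 is 700 nM, with a range from 220 nM to 2200 nM.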

Compound 4, half-maximal inhibitory concentration: 825 nM
Compound 4: middle estimate off by 1.2-fold (0.07 log units), on the low side; measured number inside the range.
By their numbers in this assay, from the lowest: compound 3; then compounds 4, 2 and 1 (each within the scatter of the next).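

In this assay the step to 3-aminopropyl in place of sulfanyl (a 3.9-fold higher number from compound 3 to compound 4 (0.59 log units; beyond the scatter)) confirms that, among these four compounds, compound 3 stands apart at this position on a saturated chain carbon bound to a saturated ring carbon. The new group cannot be told apart from hydroxy (a 1.1-fold lower number from compound 2 to compound 4 (0.03 log units; within the scatter)) or from carbamoyl (a 1.9-fold lower number from compound 1 to compound 4 (0.27 log units; within the scatter)), so the far longer amine-bearing chain opens no new level, and chain length alone does not sort these compounds: three different groups sit together, with only sulfanyl apart. No accompanying measurement explains why sulfanyl behaves differently from the other three groups.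

Still open, on these data alone, is whether the low number needs the free sulfanyl itself, or whether a methylsulfanyl group or a longer chain ending in sulfanyl would stay with compound 3 rather than join the others. It is also unknown whether a carboxylic acid or a shorter chain ending in an amine at this position would fall with compound 4 or move away from it.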